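The source may report more compounds than this note shows. Statements on the series, on what has been measured and on what is new or still open speak of the compounds shown alone.

Measured so far:
compound 1 `CC(C)(NC(=O)COc1ccc2[nH]c(=O)c(-c3cccnc3)c(CCc3ccccc3)c2c1)c1ccccc1`: 497 nM
compound 2 `CS(=O)(=O)c1c(CCc2ccccc2)c2cc(OCC(=O)NCC3CC3)ccc2[nH]c1=O`: > 10000 nM

Compound 1 `CC(C)(NC(=O)COc1ccc2[nH]c(=O)c(-c3cccnc3)c(CCc3ccccc3)c2c1)c1ccccc1` gives 497 nM in an assay on CHO-K1 cells for displacement of a labelled ligand from adenosine receptor A1 (Homo sapiens), with a stated time of 2 h; a lower number here means a stronger inhibitor, a higher number a weaker inhibitor. Compound 2 `CS(=O)(=O)c1c(CCc2ccccc2)c2cc(OCC(=O)NCC3CC3)ccc2[nH]c1=O` is a separate matter: in this assay compound 2 is recorded only as a limit, > 10000 nM, and no number is known for it. Compound 2 therefore sits at the limit of > 10000 nM in this assay, at which 1 of the 2 values shown sits, the weak end of what has been measured. Compound 1 and compound 2 differ in more than one place, so their two values are not read as a single step.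

Compound 3 `CS(=O)(=O)c1c(CCc2ccccc2)c2cc(OCC(=O)Nc3ccccc3)ccc2[nH]c1=O` is the next entry. It differs from compound 2 by phenyl in place of cyclopropylmethyl on an amide-type nitrogen; in words, phenyl in place of cyclopropylmethyl on an amide-type nitrogen. Going by the values given here, no measured step of this kind exists, so the expectation rests on compound 2 alone, which stands at the limit. The step expected is an at least 1.1-fold lower number from compound 2 to compound 3 (0.04 log units; that floor lies within the scatter), small and not clearly beyond the scatter, in either direction. Compound 3 is expected near 9000 nM, within 2000 nM to 30000 nM, with a fair chance that only a limit is reported again.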

Compound 3, inhibition constant: 1330 nM
Estimate against measurement, compound 3: 6.8-fold (0.83 log units) above; the whole stated range lies above it.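

The amide-type nitrogen is a position that responds: phenyl in place of cyclopropylmethyl gives an at least 7.5-fold lower number from compound 2 to compound 3 (0.87 log units; beyond the scatter) in this assay. Going by these compounds alone, compound 1 and compound 2 differ in more than one place, so this is the first change that can be read at a single position. Compound 2 is recorded only as a limit, so the step has a floor and no upper end: the limit of > 10000 nM in this assay, at which 1 of the 3 values shown sits.

On these data alone, it remains open whether the gain follows the aromatic ring or only the larger group, and a cyclohexyl or benzyl group on the same nitrogen would separate the two. Also open, as far as these compounds go, is whether a methoxy group or a carboxylic acid on the phenyl would shift the number further.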